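Acetoxypiperidine in Place of the Tetrahydropyridine Ring

The source may report more compounds than this note shows. Statements on the series, on what has been measured and on what is new or still open speak of the compounds shown alone.

The measured compounds:
Compound 1, `CC(C(=O)NCc1ccc(C(F)(F)F)nc1NC1CCCCC1)c1ccc(NS(C)(=O)=O)c(F)c1`, 260 nM.
Compound 2, `CC(C(=O)NCc1ccc(C(F)(F)F)nc1NCc1cccnc1)c1ccc(NS(C)(=O)=O)c(F)c1`, "not active" (no number reported).
Compound 3, `CC(C(=O)NCc1ccc(C(F)(F)F)nc1N1CC=CCC1)c1ccc(NS(C)(=O)=O)c(F)c1`, 12.1 nM.

In a functional assay on CHO-K1 cells for antagonist activity at transient receptor potential cation channel subfamily V member 1 (Homo sapiens), read by FLIPR (on this read-out higher numbers stand for weaker inhibition and lower numbers for stronger inhibition), compound 1 gives 260 nM, while compound 2 gives "not active" (no number reported) and compound 3 gives 12.1 nM. Compound 3 stands lowest of the two numbers reported, and its nearest neighbour is compound 1, separated by a 21-fold lower number from compound 1 to compound 3 (1.33 log units; beyond the scatter). The unmeasured compound 4, `CC(=O)OC1CCN(c2nc(C(F)(F)F)ccc2CNC(=O)C(C)c2ccc(NS(C)(=O)=O)c(F)c2)CC1`, differs from compound 3 on the shared core in one place: a group of 10 heavy atoms (7 carbon, 1 nitrogen, 2 oxygen; one six-membered non-aromatic ring with 1 hetero atom) in place of a group of 6 heavy atoms (5 carbon, 1 nitrogen; one six-membered non-aromatic ring with 1 hetero atom), on an aromatic carbon.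

Among the compounds with values here, no measured step bears directly on this change. Within the data shown here, the only step available, a 21-fold lower number from compound 1 to compound 3 (1.33 log units; beyond the scatter), concerns the exchange of an open-chain amine for a ring amine, and both compound 3 and compound 4 carry a ring amine; the inactivity of compound 2 is a third variation at the same aromatic carbon and also gives no guidance on the entering 4-acetoxypiperidin-1-yl group. Because the nitrogen-containing ring that compound 3 owes its low number to 12.1 nM is retained, compound 4 is expected to stay in the same region, with a modest drift to a higher number allowed for by the broad range. The estimated step is a 2.5-fold higher number from compound 3 to compound 4 (0.39 log units; beyond the scatter). Compound 4 is therefore estimated at 30 nM, between 8 nM and 150 nM.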

Compound 4, half-maximal inhibitory concentration: 139 nM
For compound 4 the middle estimate is 4.6-fold (0.67 log units) below the measured one; measured number inside the range.
By their numbers in this assay, from the lowest: compound 3; then compounds 4 and 1 (each within the scatter of the next).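

At this aromatic carbon, next to the ring nitrogen, a six-membered ring joined through its nitrogen is not enough to keep the low number of compound 3: with 4-acetoxypiperidin-1-yl in place of the ring of compound 3, this assay shows an 11-fold higher number from compound 3 to compound 4 (1.06 log units; beyond the scatter). The earlier gain over the cyclohexylamino group therefore does not extend to every ring of this kind, as the comparison with 4-acetoxypiperidin-1-yl gives a 1.9-fold lower number from compound 1 to compound 4 (0.27 log units; within the scatter), and these two groups cannot be told apart on this read-out. Nothing available accounts for the difference between compound 3 and compound 4.

The change from compound 3 to compound 4 removes the double bond of the ring and adds the acetoxy group in one step, so the compounds shown cannot divide the shift between these two parts. As far as these compounds go, a plain piperidin-1-yl group or a 4-hydroxypiperidin-1-yl group at this carbon would separate them, and it also remains open how a morpholin-4-yl group would compare with compound 3 and compound 4.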